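Chloro for Bromo: A Single Halogen Swap

This account rests on a few compounds, and the source may have more. Where it says the series, first, only, none or still open, it means among the compounds named here.

Compound 1 `CN1CCN(c2ccc(Nc3ncc(F)c(NC4CCCC4)n3)cc2)CC1` — 37200 nM
Compound 2 `COc1cc(C(=O)NC2CCN(C)CC2)ccc1Nc1ncc(Br)c(NC2CCCC2)n1` — 2500 nM

Both compounds were read in a functional assay on A549 cells (Homo sapiens) for cytotoxicity, read by MTT assay, with a stated time of 48 h; a higher number here means a weaker inhibitor, a lower number a stronger inhibitor. Compound 1 gives 37200 nM, and compound 2 gives 2500 nM, the lower of the two numbers and separated from compound 1 by a gap that lies beyond the scatter. Compound 2 thus stands as the stronger of the pair, though the two differ in several places, so no single change accounts for the gap.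

Compound 3 `COc1cc(C(=O)NC2CCN(C)CC2)ccc1Nc1ncc(Cl)c(NC2CCCC2)n1` differs from compound 2 in one place only: chloro in place of bromo on an aromatic carbon. Among the compounds with values here, no measured pair in this set isolates such a halogen exchange, so nothing here sets its size. The expectation is a step of a 1.4-fold higher number from compound 2 to compound 3 (0.15 log units; within the scatter) that stays within the scatter, or at most a modest weakening. Compound 3 is therefore estimated at 3500 nM, with a range from 1200 nM to 10000 nM.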

Compound 3, half-maximal inhibitory concentration: 5300 nM
The estimate for compound 3 lay 1.5-fold (0.18 log units) below the measured number, within the range that was stated.
By their numbers in this assay, from the lowest: compound 2; then compound 3; then compound 1.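

In this assay, the halogen on the aromatic carbon ortho to a cyclopentylamino group proves not to be freely interchangeable: with the rest of the molecule unchanged, chloro in place of bromo gives a 2.1-fold higher number from compound 2 to compound 3 (0.33 log units; beyond the scatter), a modest weakening. Within the data shown here, this is the first step in the set that isolates a single change, so the position can now be said to respond to the identity of the halogen, which the gap between the earlier compounds could not show. Nothing measured here gives a reason for the step.

Compound 1 carries fluoro at this place but also differs elsewhere, so the effect of fluoro on this series cannot be read. Going by these compounds, whether iodo, a methyl group or a nitrile here would extend the trend or break it remains open.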